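Swapping an aminophenyl arm for an aminopropyl chain

The source may report more compounds than this note shows. Statements on the series, on what has been measured and on what is new or still open speak of the compounds shown alone.

Measured compounds:
- compound 1 `Nc1cccc(Nc2c(C(=O)NCc3ccc(F)cc3)nc(Br)c3cccnc23)c1`: 8000 nM
- compound 2 `N[C@H]1CC[C@H](Nc2c(C(=O)NCc3ccc(Cl)cc3Cl)nc(Br)c3cccnc23)CC1`: "not determined" (no result reported)
- compound 3 `C[C@H](NC(=O)c1nc(Br)c2cccnc2c1N[C@H]1CC[C@H](N)CC1)c1ccc(F)cc1`: "not determined" (no result reported)

All three share one core, and they differ in the group attached to the nitrogen on that core and in the amide side chain. In a functional assay on MCF7 cells (Homo sapiens) for cytotoxicity, read by MTT assay, with a stated time of 72 h (a lower number here means a stronger inhibitor, a higher number a weaker inhibitor), compound 1 gives 8000 nM, which is a weak result. Within the data shown here, compound 1 stands alone on the numbers: in this assay compound 2 gives "not determined" (no result reported), and compound 3 gives "not determined" (no result reported), so no step between two measured compounds can be drawn.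

Compound 4 `CNCCCNc1c(C(=O)NCc2ccc(F)cc2)nc(Br)c2cccnc12` has not yet been tested. It is derived from compound 1 by one change (3-(methylamino)propyl in place of 3-aminophenyl on a nitrogen on an aromatic ring). The new substituent is a chain rather than a ring, but it keeps the same count of donors and acceptors.

Among the measured compounds shown here, since only a single number is at hand, no trend can be read from the data. The expectation is that the step of a 1.1-fold lower number from compound 1 to compound 4 (0.06 log units; within the scatter) stays modest, close to the scatter of the assay, with no clear direction. Compound 4 is therefore estimated at 7000 nM in this assay, within a broad range from 1500 nM to 30000 nM.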

Compound 4, half-maximal inhibitory concentration: > 10000 nM
Compound 4: a limit, no number; the forecaster's own chance of this, stated with the estimate: 25%; middle value at least 1.4-fold (0.15 log units) away from the limit.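

In this assay, compound 4 gives > 10000 nM, which is a limit of the assay and not a number. Replacing the aromatic ring of 3-aminophenyl with the open 3-(methylamino)propyl chain, while the rest of the molecule stays the same, gives an at least 1.2-fold higher number from compound 1 to compound 4 (0.09 log units; that floor lies within the scatter), and because only a floor is known, this step cannot be called a real change: the floor lies within the scatter. This pair is still the first direct look at this nitrogen substituent, and nothing in it points to a gain from giving up the ring, with the new compound sitting at the top of the tested range: the limit of > 10000 nM in this assay, at which 1 of the 4 values shown sits.

The compounds shown leave open whether the ring itself or the end group of the substituent matters more, as the single step changes both at once. Going by these compounds, how a longer chain, a chain ending in a simple primary amine or a carboxylic acid, or a ring carrying its amine elsewhere would read in this assay remains unknown, and a number for compound 4 would need a result inside the range of the assay.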